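The compounds below may be only part of what the source reports. "The series", "measured", "known", "first", "only" and "open" are said of these compounds alone.

The measured compounds:
Compound 1, `CCCCN(C)c1nc(C(C)(C)C)ccc1CNC(=O)C(C)c1ccc(NS(C)(=O)=O)c(F)c1`: in an assay on cells for antagonist activity at transient receptor potential cation channel subfamily V member 1 (Homo sapiens), read by FLIPR and calcium flux, with a stated time of 6 min (on this read-out lower numbers stand for stronger inhibition and higher numbers for weaker inhibition), compound 1 gives 1.2 nM.
Compound 2, `CCCN(CCC)c1nc(C(C)(C)C)ccc1CNC(=O)C(C)c1ccc(NS(C)(=O)=O)c(F)c1`: in this assay compound 2 gives 2.5 nM.
Compound 3, `CCCCCCOc1nc(C(C)(C)C)ccc1CNC(=O)C(C)c1ccc(NS(C)(=O)=O)c(F)c1`: in this assay compound 3 gives 2.7 nM.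

Among these three numbers compound 2 holds the second highest. The gap to its nearest neighbour, a 1.1-fold higher number from compound 2 to compound 3 (0.03 log units; within the scatter), lies within the scatter; the gap to its furthest, a 2.1-fold higher number from compound 1 to compound 2 (0.32 log units; beyond the scatter), lies beyond it. Compound 4, `CCOCCOc1nc(C(C)(C)C)ccc1CNC(=O)C(C)c1ccc(NS(C)(=O)=O)c(F)c1`, has not yet been measured. It differs from compound 2 in one place: 2-ethoxyethoxy in place of dipropylamino on an aromatic carbon. The step that bears most on this change is a 1.1-fold higher number from compound 2 to compound 3 (0.03 log units; within the scatter), where hexyloxy likewise replaced dipropylamino and the number did not move beyond the scatter; the step of a 2.3-fold higher number from compound 1 to compound 3 (0.35 log units; beyond the scatter), with hexyloxy in place of butyl(methyl)amino, was only modest. Replacing dipropylamino with 2-ethoxyethoxy is therefore expected to shift this assay little, if at all, with any drift more likely toward a higher number. Compound 4 is expected to give 3.5 nM, between 1.5 nM and 8 nM. That would be an expected step of a 1.4-fold higher number from compound 2 to compound 4 (0.15 log units; within the scatter).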

Compound 4, inhibition constant: 23.9 nM
Compound 4: the middle estimate sits 6.8-fold (0.83 log units) below what was measured; measured number outside the range, above it.
By their numbers in this assay, from the lowest: compound 1; then compounds 2 and 3 (each within the scatter of the next); then compound 4.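

In this assay, compound 2 and compound 3 had stood within the scatter of each other, so replacing the dipropylamino group with an oxygen-linked chain had looked harmless, but an 8.9-fold higher number from compound 3 to compound 4 (0.95 log units; beyond the scatter) shows that this position still responds when the oxygen on the aromatic carbon is kept and only ethoxy replaces butyl further along the chain. The changes a 9.6-fold higher number from compound 2 to compound 4 (0.98 log units; beyond the scatter) and a 20-fold higher number from compound 1 to compound 4 (1.30 log units; beyond the scatter) are far larger than the hexyloxy steps, so the atom attached to the aromatic carbon does not by itself set the number here. Nothing available gives a reason for this jump.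

The compounds shown leave open whether a shorter plain chain such as butoxy would stay close to hexyloxy. They also leave open whether 2-methoxyethoxy or a chain ending in an amine would follow 2-ethoxyethoxy.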